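Changing the Group on Sulfur in Compound 1

The source may hold more compounds than are shown below. What is called first, only, known or untested is meant among the compounds shown, and "the series" means these compounds.

In a functional assay on MGC-803 cells (Homo sapiens) for antiproliferative activity, read by MTT assay, with a stated time of 48 h (a lower number here means a stronger inhibitor, a higher number a weaker inhibitor), compound 1 `COc1ccc(CN(C(=O)CSc2nc3ccc(OC)cc3s2)c2cc(OC)c(OC)c(OC)c2)cc1` gives 1270 nM. Going by the values given here, its only measured neighbour, compound 2 `COc1ccc(CN(C(=O)CCCSc2nc3ccccc3o2)c2cc(OC)c(OC)c(OC)c2)cc1`, gives 1290 nM, so the two stand level on the numbers available. Among the compounds with values here, the single measured step, a 1.0-fold higher number from compound 1 to compound 2 (0.01 log units; within the scatter), lies within the scatter. That step exchanges one group for another on a saturated chain carbon bound to a carbonyl carbon, and in this pair the exchange leaves the reading unmoved.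

Compound 3 `COc1ccc(CN(C(=O)CSc2nc3ccccc3[nH]2)c2cc(OC)c(OC)c(OC)c2)cc1` has not yet been measured. It carries 1H-benzimidazol-2-yl in place of 6-methoxy-1,3-benzothiazol-2-yl on a sulfur. Within the data shown here, no measured pair shows this exact exchange, so the step to compound 2 is a thin guide, resting on a single comparison. Among the measured compounds shown here, with only that flat step to go on, no clear shift in either direction can be expected, and the range must stay wide. The expected step in this assay is a 1.2-fold higher number from compound 1 to compound 3 (0.07 log units; within the scatter), which would stay within the scatter. Compound 3 is estimated at 1500 nM, with an expected range from 500 nM to 4500 nM.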

Compound 3, half-maximal inhibitory concentration: 1230 nM
Compound 3: middle estimate off by 1.2-fold (0.09 log units), on the high side; measured number inside the range.
By their numbers in this assay, from the lowest: compounds 3, 1 and 2 (each within the scatter of the next).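

Read in this assay, putting 1H-benzimidazol-2-yl in place of 6-methoxy-1,3-benzothiazol-2-yl on a sulfur gives a 1.0-fold lower number from compound 1 to compound 3 (0.01 log units; within the scatter), and this exchange leaves the chain to the carbonyl as it stands in compound 1. The two groups differ in size and in their counts, with 1 hydrogen-bond donor entering where 0 hydrogen-bond donors leave, yet in this pair those differences come with no separation in the readings. The wider exchange of (1H-benzimidazol-2-yl)sulfanyl in place of 2-((1,3-benzoxazol-2-yl)sulfanyl)ethyl gives a 1.0-fold lower number from compound 2 to compound 3 (0.02 log units; within the scatter), so all three compounds stand level, and no information here explains that flatness.

Each group shown on the sulfur pairs a five-membered aromatic ring with a six-membered one, so it remains open whether a lone phenyl ring, an amine or a carboxylic acid at this place would also stand level. Also open, on these data alone, is whether any group on this sulfur can separate itself from these three by more than the scatter.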